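A few compounds are considered here, and "the series" means these few. Any claim that something is new, unique, unknown or untested is made for them only; others in the source may bear on it.

Compound 3, `O=c1[nH]/c(=N\OCCCc2ccc([N+](=O)[O-])cc2)ccn1[C@@H]1O[C@H](COP(=O)(O)OP(=O)(O)OP(=O)(O)O)[C@@H](O)[C@H]1O`, is measured in a functional assay on 1321-N1 cells for agonist activity at P2Y purinoceptor 6 (Homo sapiens), read by scintillation counting and inositol phosphate accumulation (a higher number here means that more compound is needed for the effect, a lower number that less compound is needed), where compound 3 gives 1330 nM. This is the highest of the three numbers at hand. Compound 1, `O=C(O)CCCO/N=c1/ccn([C@@H]2O[C@H](COP(=O)(O)OP(=O)(O)OP(=O)(O)O)[C@@H](O)[C@H]2O)c(=O)[nH]1`, gives 697 nM, and the step of a 1.9-fold higher number from compound 1 to compound 3 (0.28 log units; within the scatter) stays within the scatter, so these two cannot be told apart. Compound 2, `O=c1[nH]/c(=N\OCCCc2ccc(I)cc2)ccn1[C@@H]1O[C@H](COP(=O)(O)OP(=O)(O)OP(=O)(O)O)[C@@H](O)[C@H]1O`, gives 90 nM, and the step of a 15-fold higher number from compound 2 to compound 3 (1.17 log units; beyond the scatter) is the large one in this set.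

Compound 4, `COc1ccc(CCCO/N=c2/ccn([C@@H]3O[C@H](COP(=O)(O)OP(=O)(O)OP(=O)(O)O)[C@@H](O)[C@H]3O)c(=O)[nH]2)cc1`, differs from compound 3 in one place: methoxy in place of nitro on an aromatic carbon. The measured step that bears on this change is a 15-fold higher number from compound 2 to compound 3 (1.17 log units; beyond the scatter), which shows that exchanging the group on this aromatic carbon can shift the number a long way. Within the data shown here, no measured compound carries methoxy, so the direction of the new step rests on no direct precedent; the two substituted aryl compounds bracket compound 1, and methoxy is expected to land between them, nearer compound 3. The step from compound 3 to compound 4 is therefore expected to be modest, a 2.7-fold lower number from compound 3 to compound 4 (0.42 log units; beyond the scatter). Compound 4 is estimated at 500 nM, with a range from 150 nM to 1700 nM.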

Compound 4, half-maximal effective concentration: 277 nM
Estimate against measurement, compound 4: 1.8-fold (0.26 log units) above; the range from low to high includes it.
By their numbers in this assay, from the lowest: compound 2; then compound 4; then compounds 1 and 3 (each within the scatter of the next).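

Methoxy in place of nitro on this aromatic carbon gives a 4.8-fold lower number from compound 3 to compound 4 (0.68 log units; beyond the scatter) in this assay and shows that a third group here gives a number of its own, not just that of iodo or nitro. Methoxy in place of iodo gives a 3.1-fold higher number from compound 2 to compound 4 (0.49 log units; beyond the scatter) and places methoxy clearly apart from iodo too, so all three groups at this carbon can now be told apart. The 4-methoxyphenyl group in place of carboxy gives a 2.5-fold lower number from compound 1 to compound 4 (0.40 log units; beyond the scatter) and, like 4-iodophenyl but unlike 4-nitrophenyl, ends up clearly apart from carboxy, so the outcome of that exchange depends on the group on the aromatic ring.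

Nothing measured here explains the order of these three groups. Going by these compounds, whether an amine or a hydroxyl group on this aromatic carbon would give a lower or a higher number stays open.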